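Compound 2 to compound 4: a new group on the carbonyl

The source may hold more compounds than are shown below. What is called first, only, known or untested is meant among the compounds shown, and "the series" means these compounds.

Values in an ADME assay on microsomes from liver (Homo sapiens) for metabolic stability, read by LC-MS, with a stated time of 30 min, tested at 1 uM; on this read-out lower numbers stand for a less stable compound and higher numbers for a more stable compound:
Compound 1 `O=C(NCc1ccc(S(=O)(=O)c2ccccc2)cc1)c1ccc2ncncc2c1`: 24%
Compound 2 `O=C(NCc1ccc(S(=O)(=O)N2CCCCC2)cc1)c1cnc2nccn2c1`: 64%
Compound 3 `O=C(NCc1ccc(S(=O)(=O)c2cc(F)cc(F)c2)cc1)c1cnc2nccn2c1`: 78%

Of these three, compound 2 stands second highest, below compound 3 and well above compound 1. Compound 4 `O=C(NCc1ccc(S(=O)(=O)N2CCCCC2)cc1)c1ccn2cncc2c1` keeps the piperidin-1-yl on the sulfonyl sulfur and changes the group on the carbonyl carbon: a group of 9 heavy atoms (7 carbon, 2 nitrogen; one five-membered aromatic ring with 2 hetero atoms, one six-membered aromatic ring with 1 hetero atom) in place of a group of 9 heavy atoms (6 carbon, 3 nitrogen; one five-membered aromatic ring with 2 hetero atoms, one six-membered aromatic ring with 2 hetero atoms), on a carbonyl carbon. Within the data shown here, no measured step covers this change. The only one, a number 14 percentage points higher from compound 2 to compound 3 (beyond the scatter), lies at the sulfonyl sulfur and serves only as a gauge of size. Compound 1, at 24%, carries another group on the carbonyl carbon, but it also differs at the sulfonyl sulfur, so it gives only a weak hint of a lower number. The expected step is modest and downward, a number 14 percentage points lower from compound 2 to compound 4 (beyond the scatter), and it is uncertain. For compound 4 the estimate is 50%, with an expected range of 25% to 72%.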

Compound 4, percent of the compound remaining: 54%
Estimate against measurement, compound 4: 4 percentage points below, within the range that was stated.
By their numbers in this assay, from the lowest: compound 1; then compounds 4 and 2 (each within the scatter of the next); then compound 3.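

In this assay, among these compounds, the new group on the carbonyl carbon gives a number 10 percentage points lower from compound 2 to compound 4 (within the scatter) and so provides the first step that can be read at this position. With piperidin-1-yl kept on the sulfonyl sulfur, the six-membered aromatic ring with 1 hetero atom and the one with 2 hetero atoms cannot be told apart on this read-out. Nothing available explains this result. On these data alone, it remains open whether the same exchange would read alike with 3,5-difluorophenyl on the sulfonyl sulfur. Also open, as far as these compounds go, is how a single phenyl ring, or a ring bearing a carboxylic acid, would fare on the carbonyl carbon.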